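The compounds below may be only part of what the source reports. "The series", "measured", "known", "first", "only" and "open" are said of these compounds alone.

In a functional assay on HCT-116 cells (Homo sapiens) for inhibition, read by MTT assay, with a stated time of 72 h (on this read-out higher numbers stand for weaker inhibition and lower numbers for stronger inhibition), compound 1 (`Nc1ccccc1NC(=O)c1ccc(CNC(=O)/C=C/c2cnc3ccccn23)cc1`) gives 2300 nM, compound 2 (`Nc1ccccc1NC(=O)c1ccc(CNC(=O)/C=C/c2c[nH]c3ccccc23)cc1`) gives 1220 nM and compound 3 (`Nc1ccccc1NC(=O)c1ccc(CNC(=O)/C=C/c2cnc3cccnn23)cc1`) gives 1260 nM. Compound 3 therefore stands level with the other two, and no order can be drawn among the three: a 1.8-fold lower number from compound 1 to compound 3 (0.26 log units; within the scatter) and a 1.0-fold higher number from compound 2 to compound 3 (0.01 log units; within the scatter) both lie within the scatter, as does a 1.9-fold lower number from compound 1 to compound 2 (0.28 log units; within the scatter).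

Compound 4 (`Cc1nc2ccccn2c1/C=C/C(=O)NCc1ccc(C(=O)Nc2ccccc2N)cc1`) departs from compound 3 on a double-bonded chain carbon bound to a double-bonded chain carbon: a group of 10 heavy atoms (8 carbon, 2 nitrogen; one five-membered aromatic ring with 2 hetero atoms, one six-membered aromatic ring with 1 hetero atom) in place of a group of 9 heavy atoms (6 carbon, 3 nitrogen; one five-membered aromatic ring with 2 hetero atoms, one six-membered aromatic ring with 2 hetero atoms), on a double-bonded chain carbon bound to a double-bonded chain carbon. The measured step nearest to this change is a 1.8-fold lower number from compound 1 to compound 3 (0.26 log units; within the scatter), which exchanges the same two kinds of ring system in the opposite direction and stays within the scatter. Among the measured compounds shown here, no measured step shows the effect of the larger group of 10 heavy atoms, which widens the uncertainty.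

The estimated step is a 1.3-fold higher number from compound 3 to compound 4 (0.13 log units; within the scatter), and it is not expected to go beyond the scatter in this assay. Compound 4 is expected at 1700 nM, with an estimated range of 750 nM to 3900 nM.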

Compound 4, half-maximal inhibitory concentration: 1430 nM
The estimate for compound 4 lay 1.2-fold (0.08 log units) above the measured number; the range from low to high includes it.
By their numbers in this assay, from the lowest: compounds 2, 3, 4 and 1 (each within the scatter of the next).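

In this assay, methyl in place of hydrogen on an aromatic carbon gives a 1.6-fold lower number from compound 1 to compound 4 (0.21 log units; within the scatter), so this single added group on the ring system does not move the number beyond the scatter. The group of 10 heavy atoms also stands level with the other two ring systems on the double-bonded chain carbon, with a 1.1-fold higher number from compound 3 to compound 4 (0.05 log units; within the scatter) and a 1.2-fold higher number from compound 2 to compound 4 (0.07 log units; within the scatter), and all four groups at this place remain without any order in this assay. No measurement is available that bears on why these numbers stand so close.

The compounds shown leave open whether an amine or a carboxylic acid in place of the methyl would carry the number beyond the scatter. They also leave open whether a longer chain, such as ethyl, on that aromatic carbon would do so.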